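A few compounds are considered here, and "the series" means these few. Any claim that something is new, unique, unknown or untested is made for them only; others in the source may bear on it.

Measured compounds:

compound 1, `c1ccc(-c2nc3ccc[nH]c-3n2)cc1`: 8 mg/kg
compound 2, `Cc1cccc(-c2nc3ccc[nH]c-3n2)c1`: 2.8 mg/kg
compound 3, `Cc1ccccc1-c1nc2cc[nH]cc-2n1`: 2.2 mg/kg

In a functional assay on the whole organism with Canis familiaris (Canis lupus familiaris) as the target (on this read-out higher numbers stand for an effect only at larger amounts of compound and lower numbers for an effect already at smaller amounts), compound 1 gives 8 mg/kg and compound 2 gives 2.8 mg/kg. For the measured compounds named here, the one step measured between compounds that differ in one place is a 2.9-fold lower number from compound 1 to compound 2 (0.46 log units; beyond the scatter), brought about by methyl in place of hydrogen on an aromatic carbon. Compound 3 carries a different core; how the core of compound 3 differs from that of compound 1 is not broken down here. The values of compound 2 and compound 3 lie within the scatter of each other.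

Compound 4, `Cc1ccc(-c2nc3cc[nH]cc-3n2)c(C)c1`, is not yet measured. It differs from compound 3 by methyl in place of hydrogen on an aromatic carbon. The change is of the same kind as that from compound 1 to compound 2, not the same: in compound 4 the methyl enters meta to a methyl group and para to a group of 9 heavy atoms, whereas in compound 2 it enters meta to a group of 9 heavy atoms, and the cores differ. Compound 4 is therefore expected to give 1.5 mg/kg, between 0.7 mg/kg and 4 mg/kg, a step of a 1.5-fold lower number from compound 3 to compound 4 (0.17 log units; within the scatter), smaller than the earlier one because the step of a 2.9-fold lower number from compound 1 to compound 2 (0.46 log units; beyond the scatter) rests on a different core and a different place.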

Compound 4, dose for half-maximal effect: 1.4 mg/kg
Estimate against measurement, compound 4: 1.1-fold (0.03 log units) above; the measured number falls inside the stated range.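

On the core of compound 3, methyl in place of hydrogen on an aromatic carbon gives a 1.6-fold lower number from compound 3 to compound 4 (0.20 log units; within the scatter) in this assay and so, taken alone, cannot be told from repeat measurement. The step nevertheless does not differ measurably from the one on the core of compound 1, so the two cores give no sign that the change behaves differently from one to the other: the same change on two cores in this assay, a 2.9-fold lower number (0.46 log units; beyond the scatter) from compound 1 to compound 2 and a 1.6-fold lower number (0.20 log units; within the scatter) from compound 3 to compound 4, 1.8-fold (0.26 log units) apart, within the scatter of two such steps. For the compounds shown here, this does not show that the change transfers with the same size, for only two pairs are at hand, the methyl sits in a different place in each, and the effect of the core therefore cannot be separated from that of the place.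

The compounds shown leave open whether a group other than methyl, such as a chlorine, a methoxy group or an amine, would follow the same course on either core. They also leave open what a longer chain would do at the place meta to a methyl group and para to a group of 9 heavy atoms.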